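Compound 2 to its 4-hydroxy-3,5-dimethoxyphenyl analogue

A few compounds are considered here, and "the series" means these few. Any claim that something is new, unique, unknown or untested is made for them only; others in the source may bear on it.

In a functional assay on MCF7 cells (Homo sapiens) for antiproliferative activity, read by sulforhodamine B assay, with a stated time of 48 h (on this read-out lower numbers stand for stronger inhibition and higher numbers for weaker inhibition), compound 2 `COc1ccc(C=C(C(=O)/C=C/c2cccc(OC)c2OC)C(=O)/C=C/c2cccc(OC)c2OC)cc1OC` gives 560 nM, and compound 3 `COc1cccc(/C=C/C(=O)C(=Cc2cc(OC)c(OC)c(OC)c2)C(=O)/C=C/c2cccc(OC)c2OC)c1OC` gives 840 nM. These two numbers sit within the scatter of each other, so compound 2 stands level with compound 3.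

Compound 1 `COc1ccc(OC)c(/C=C/C(=O)/C=C(O)/C=C/c2cc(OC)ccc2OC)c1` gives > 50000 nM, which is a limit of the assay and not a number. Within the data shown here, it offers no measured step for the comparison here.

Compound 4 `COc1cc(C=C(C(=O)/C=C/c2cccc(OC)c2OC)C(=O)/C=C/c2cccc(OC)c2OC)cc(OC)c1O` is not yet measured. Its change from compound 2 is 4-hydroxy-3,5-dimethoxyphenyl in place of 3,4-dimethoxyphenyl on a double-bonded chain carbon bound to a double-bonded chain carbon, with 4-hydroxy-3,5-dimethoxyphenyl in place of 3,4-dimethoxyphenyl on a double-bonded chain carbon bound to a double-bonded chain carbon.

Among the measured compounds shown here, the only measured step at this group is a 1.5-fold higher number from compound 2 to compound 3 (0.18 log units; within the scatter), with methoxy in place of hydrogen on an aromatic carbon. For the measured compounds named here, no measured step introduces the hydroxy group, so the range is kept wide. No step beyond the scatter is expected in this assay.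

The estimated step is a 1.3-fold higher number from compound 2 to compound 4 (0.10 log units; within the scatter).

For compound 4 the expected value is 700 nM, with an estimated range from 250 nM to 2200 nM.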

Compound 4, half-maximal inhibitory concentration: 460 nM
Beside the measured number, compound 4's estimate is 1.5-fold (0.18 log units) above it; low and high end bracket the measured number.
By their numbers in this assay, from the lowest: compounds 4, 2 and 3 (each within the scatter of the next). At a limit, above all of these: compound 1.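

In this assay, 4-hydroxy-3,5-dimethoxyphenyl in place of 3,4-dimethoxyphenyl on a double-bonded chain carbon bound to a double-bonded chain carbon gives a 1.2-fold lower number from compound 2 to compound 4 (0.09 log units; within the scatter), the first measured case of a hydroxy group on this phenyl ring. Hydrogen in place of methyl on an oxygen on an aromatic ring gives a 1.8-fold lower number from compound 3 to compound 4 (0.26 log units; within the scatter), so a hydroxy group and a methoxy group in the same place read level here, and all three phenyl groups measured at this position stand within the scatter of one another. No measured property in these notes bears on this result.

Going by these compounds, whether an amine or a carboxylic acid on this phenyl ring would also stay level remains open. Also open, on these data alone, is whether the level holds with a longer chain on the oxygen in place of methyl.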